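The source may hold more compounds than are shown below. What is called first, only, known or untested is meant among the compounds shown, and "the series" means these compounds.

Measured compounds and their values:

compound 1, `O=C(c1ncc(-c2ccccn2)o1)[C@@H]1COc2cc(OCc3ccccc3)ccc2C1` — 17 nM
compound 2, `O=C(c1ncco1)[C@H]1COc2cc(OCc3ccccc3)ccc2C1` — 20 nM

Both were measured in an assay for inhibition of Fatty-acid amide hydrolase 1 (Rattus norvegicus), using a Dixon plot; a higher number here means a weaker inhibitor, a lower number a stronger inhibitor. Compound 1 gives the lower number of the two, but compound 2 sits within the scatter of it, so the pair shows no separation that can be read as an order. Within the data shown here, no step between measured compounds that differ in one place is available, so the series gives no measured step to lean on.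

The next compound, compound 3, `O=C(c1ncc(-c2ccccn2)o1)[C@@H]1COc2cc(Oc3ccccc3)ccc2C1`, differs from compound 1 in one place: phenyl in place of benzyl on an oxygen on an aromatic ring. The shared core, the ketone and the oxazole bearing the pyridyl group stay as in compound 1.

Nothing in the two measured values speaks directly to this change. On these data alone, with compound 1 at 17 nM and compound 2 close to it despite a different oxazole substituent, the benzyl group on the ring oxygen appears in both and its loss is untested. The expectation is a modest step toward a higher number, a 2.6-fold higher number from compound 1 to compound 3 (0.42 log units; beyond the scatter), beyond the scatter but not large. Compound 3 is therefore estimated at 45 nM, with a range from 12 nM to 170 nM.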

Compound 3, inhibition constant: 27 nM
For compound 3 the middle estimate is 1.7-fold (0.22 log units) above the measured one; the measured number falls inside the stated range.
By their numbers in this assay, from the lowest: compounds 1, 2 and 3 (each within the scatter of the next).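

In this assay, the step from benzyloxy to phenoxy gives the series its first reading at this position: a 1.6-fold higher number from compound 1 to compound 3 (0.20 log units; within the scatter) shows that the two compounds cannot be told apart in this assay. On the shared core with the pyridyl-bearing oxazole, phenyl in place of benzyl on the oxygen on the aromatic ring therefore leaves the inhibition constant within the scatter, and the benzyl group is not required to keep this pair in the same range. This holds for this one pair only, and nothing measured here bears on why the two groups read alike.

On these data alone, both groups tested on this oxygen carry a six-membered aromatic ring of carbon only, so it remains open how the position responds to a group without that ring, such as a longer alkyl chain, an amine or a carboxylic acid. Also open is whether the exchange of benzyl for phenyl gives the same reading on the unsubstituted oxazole of compound 2, and what the pyridyl group contributes alone, since no pair shown isolates that group in one place.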